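This account rests on a few compounds, and the source may have more. Where it says the series, first, only, none or still open, it means among the compounds named here.

In a toxicity assay on GES1 cells (Homo sapiens) for inhibition, read by MTT assay, with a stated time of 72 h (a lower number here means a stronger inhibitor, a higher number a weaker inhibitor), compound 1 `COc1ccc(CSc2nc3nc(C)cc(N4CC[C@@H](C)[C@@H](N(C)c5ncnc6[nH]ccc56)C4)n3n2)cc1` reads > 100000 nM, which is a limit of the assay and not a number. Among the compounds with values here, compound 2 `Cc1cc(N2CC[C@@H](C)[C@@H](N(C)c3ncnc4[nH]ccc34)C2)n2nc(SCc3ccc(C(F)(F)F)cc3)nc2n1` gives 17300 nM, the only actual number so far. Compound 3 `C#CSc1nc2nc(C)cc(N3CC[C@@H](C)[C@@H](N(C)c4ncnc5[nH]ccc45)C3)n2n1` carries ethynyl in place of 4-(trifluoromethyl)benzyl on a sulfur. Within the data shown here, one measured step bears on this, and only indirectly: an at least 5.7-fold lower number from compound 1 to compound 2 (0.76 log units; beyond the scatter), with trifluoromethyl in place of methoxy on an aromatic carbon. The ring holding that trifluoromethyl leaves in compound 3, so the lower number of compound 2 at 17300 nM is not expected to carry over. Among the measured compounds shown here, no measured step covers this exchange directly, so the size is uncertain. The estimated step is expected to be a 2.9-fold higher number from compound 2 to compound 3 (0.46 log units; beyond the scatter). For compound 3 the estimate is 50000 nM, with an expected range of 12000 nM to 100000 nM.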

Compound 3, half-maximal inhibitory concentration: > 100000 nM
Compound 3: only a limit was reported (the forecaster's own chance of this, stated with the estimate: 40%); at least 2.0-fold (0.30 log units) between middle value and limit.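

In this assay, ethynyl in place of 4-(trifluoromethyl)benzyl on the sulfur gives an at least 5.7-fold higher number from compound 2 to compound 3 (0.76 log units; beyond the scatter), so a small group at this position does not retain the measurable toxicity of compound 2. Compound 3 reads > 100000 nM, a limit of the assay and not a number, which leaves 4-(trifluoromethyl)benzyl as the only one of the three sulfur substituents shown that gives an actual value. The step from compound 1 to compound 3 cannot be read because neither compound has an actual value: the limit of > 100000 nM in this assay, at which 2 of the 3 values shown sit.

On these data alone, it remains open whether the value of compound 2 depends on the trifluoromethyl or on the aromatic ring that carries it. An unsubstituted benzyl or a longer alkyl chain on the sulfur would bear on this, and a carboxylic acid on that ring would test another kind of substituent.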